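Removing the Benzyl Arm from a Weak Antagonist

The source may hold more compounds than are shown below. What is called first, only, known or untested is meant among the compounds shown, and "the series" means these compounds.

Measured compounds in an assay on HEK293 cells for antagonist activity at Toll-like receptor 9 (Homo sapiens), read by spectrophotometry; on this read-out higher numbers stand for weaker inhibition and lower numbers for stronger inhibition:
- compound 1 `CCN1CCN(CCCn2cnc3c(N4CCN(C(=O)C5CCCC5)CC4)nc(NCc4ccc(N(CC)CC)cc4)nc32)CC1`: 8800 nM
- compound 2 `CCN1CCN(CCCn2cnc3c(N4CCN(CC)CC4)nc(NCc4ccc(N(CC)CC)cc4)nc32)CC1`: 440 nM
- compound 3 `Fc1ccc(CNc2nc(N3CCN(C4CCCC4)CC3)c3ncn(CCCN4CCCC4)c3n2)cc1`: 100 nM

Among these three, compound 1 gives the highest number, that is the weakest inhibition. Its nearest neighbour is compound 2, which differs from it only by an ethyl in place of a cyclopentylcarbonyl on an amine nitrogen in a ring, and that single exchange gave a 20-fold lower number from compound 1 to compound 2 (1.30 log units; beyond the scatter). Compound 3 lies further away still, with a lower number than compound 1 by a wide margin, but it differs from compound 1 in several places at once, so its value alone shows no single effect.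

The new compound, compound 4 `CCN1CCN(CCCn2cnc3c(N4CCN(C(=O)C5CCCC5)CC4)nc(N)nc32)CC1`, keeps the cyclopentylcarbonyl of compound 1 and changes a different part: hydrogen in place of 4-(diethylamino)benzyl on a nitrogen on an aromatic ring. For the measured compounds named here, none of the measured steps touches this nitrogen, so there is no direct precedent. Going by the values given here, all three measured compounds carry a benzyl-type group on that nitrogen, and the one structural change that was measured moved the number by a large amount. Stripping an arm of that size from the weakest compound is therefore expected to give a step of a 3.4-fold higher number from compound 1 to compound 4 (0.53 log units; beyond the scatter) towards a higher number in this assay, with wide uncertainty. The estimate for compound 4 is 30000 nM, expected to fall between 7000 nM and 120000 nM.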

Compound 4, half-maximal inhibitory concentration: > 30000 nM
Compound 4: no number, only a limit; the forecaster's own chance of this, stated with the estimate: 35%; the middle value lies on the limit itself.
By their numbers in this assay, from the lowest: compound 3; then compound 2; then compound 1. At a limit, above all of these: compound 4.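

Compound 4 stands at a limit of the assay rather than at a number: the limit of > 30000 nM in this assay, at which 1 of the 4 values shown sits.

The earlier compounds shown here all carry a benzyl-type group on this nitrogen, so they could not show what losing it does, and hydrogen in place of 4-(diethylamino)benzyl now gives an at least 3.4-fold higher number from compound 1 to compound 4 (0.53 log units; beyond the scatter). That step is only a lower bound, yet it shows that in this setting, with the cyclopentylcarbonyl kept, removing the whole arm with its six-membered aromatic ring leaves inhibition weaker still than the already weak level of compound 1, with no measurable number left in this assay.

Going by these compounds, it remains open which part of the arm matters, for instance whether a plain benzyl without the diethylamino group, or a single methyl on the same nitrogen, would keep the number close to that of compound 1. Also open, on these data alone, is whether the same exchange would move the number as far starting from compound 2, which carries ethyl in place of the cyclopentylcarbonyl and gives 440 nM.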